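The source may report more compounds than this note shows. Statements on the series, on what has been measured and on what is new or still open speak of the compounds shown alone.

Notes on the series, read in a functional assay on MIA PaCa-2 cells (Homo sapiens) for cytotoxicity, read by WST assay, with a stated time of 48 h; on this read-out higher numbers stand for weaker inhibition and lower numbers for stronger inhibition. Compound 3 `COc1ccc2c(C(=O)/C(C#N)=C/c3c[nH]c4ccccc34)c[nH]c2c1` gives > 50000 nM, which is a limit and not a number. Compound 2 `COc1ccc2c(C(=O)/C(C#N)=C/c3c[nH]c4ccc(OC)cc34)c[nH]c2c1` gives > 50000 nM, also a limit. The series thus gathers at the limit of > 50000 nM in this assay, at which 2 of the 3 values shown sit. Among the measured compounds shown here, compound 1 `COc1ccc2c(C(=O)/C(C#N)=C/c3cn(Cc4ccc(Cl)cc4)c4ccccc34)c[nH]c2c1` gives 40400 nM, the only true number so far.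

Compound 4 `COc1ccc(Cn2cc(/C=C(\C#N)C(=O)c3c[nH]c4cc(OC)ccc34)c3ccccc32)cc1` differs from compound 3 by 4-methoxybenzyl in place of hydrogen on an aromatic nitrogen. The nearest measured change is hydrogen in place of 4-chlorobenzyl on that nitrogen, an at least 1.2-fold higher number from compound 1 to compound 3 (0.09 log units; that floor lies within the scatter). On these data alone, its floor is small, and its full size stays open. The change of hydrogen in place of methoxy on an aromatic carbon, a step that the two limits leave unreadable from compound 2 to compound 3, gives no usable size.

The expectation therefore rests on compound 1 at 40400 nM, with only a modest shift toward stronger inhibition. The estimated change is an at least 1.5-fold lower number from compound 3 to compound 4 (0.19 log units; that floor lies within the scatter), and it may not exceed the scatter. For compound 4 the expected value is 32000 nM, with an estimated range from 12000 nM to 50000 nM.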

Compound 4, half-maximal inhibitory concentration: > 50000 nM
Compound 4 ended at the assay's limit (the forecaster's own chance of this, stated with the estimate: 40%); middle value at least 1.5-fold (0.19 log units) from the limit.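

Methoxy in place of chloro on an aromatic carbon of the group on the aromatic nitrogen gives an at least 1.2-fold higher number from compound 1 to compound 4 (0.09 log units; that floor lies within the scatter), so this floor does not separate the two groups in this assay. The result for compound 4 is a limit, which shows that a substituted benzyl group on that nitrogen does not by itself yield a true number; among the compounds shown, only the 4-chlorobenzyl group of compound 1 does. The step with hydrogen on that nitrogen cannot be read, and the series gathers further at one end: the limit of > 50000 nM in this assay, at which 3 of the 4 values shown sit.

On these data alone, whether an amine or a carboxylic acid on the benzyl group, or a longer chain on that nitrogen, would give a true number stays open. Among the compounds shown here, with compound 1 as the only true number, the full size of its gap to the other compounds also stays open.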